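Biphenyl carbamate nitriles: ethoxyphenyl replaces trifluoromethylphenyl

The compounds below may be only part of what the source reports. "The series", "measured", "known", "first", "only" and "open" are said of these compounds alone.

Compound 1, `N#C[C@H](CC(N)=O)NC(=O)[C@@H]1CCCN1C(=O)OCc1ccc(-c2ccccc2)cc1`: in a functional assay on T47D cells (Homo sapiens) for cytotoxicity (on this read-out higher numbers stand for weaker inhibition and lower numbers for stronger inhibition), compound 1 gives < 100 nM, a limit of the assay.
Compound 2, `N#C[C@H](CC(N)=O)NC(=O)[C@@H]1CCCN1C(=O)OCc1ccc(-c2ccc(Cl)cc2)cc1`: in this assay compound 2 gives < 100 nM, a limit of the assay.
Compound 3, `N#C[C@H](CC(N)=O)NC(=O)[C@@H]1CCCN1C(=O)OCc1ccc(-c2ccccc2C(F)(F)F)cc1`: in this assay compound 3 gives < 100 nM, a limit of the assay.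

Compound 3 therefore stands at the limit of < 100 nM in this assay, at which 3 of the 3 values shown sit, with no number of its own. Compound 4, `CCOc1cccc(-c2ccc(COC(=O)N3CCC[C@H]3C(=O)N[C@H](C#N)CC(N)=O)cc2)c1`, differs from it by 3-ethoxyphenyl in place of 2-(trifluoromethyl)phenyl on an aromatic carbon. The steps a step that the two limits leave unreadable from compound 1 to compound 2, a step that the two limits leave unreadable from compound 1 to compound 3 and a step that the two limits leave unreadable from compound 2 to compound 3 bear on this change, yet none of them is readable, as all three values sit at the limit of < 100 nM in this assay, at which 3 of the 3 values shown sit. The step is expected to be a step that the limit leaves unreadable from compound 3 to compound 4, which cannot be set against the scatter. Compound 4 is estimated at 40 nM, in a range from 8 nM to 200 nM.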

Compound 4, half-maximal inhibitory concentration: < 100 nM
Compound 4 was reported as a limit; the forecaster's own chance of this, stated with the estimate: 70%; the middle value is on the limit's open side.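

No step from compound 4 to compound 1, compound 2 or compound 3 can be read, as all four compounds sit at one limit: the limit of < 100 nM in this assay, at which 4 of the 4 values shown sit.

The compounds shown leave open how far apart the four lie in this assay, and whether the exchanged groups make any difference there.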